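Working notes: aryl substituent swap on compound 2

This account rests on a few compounds, and the source may have more. Where it says the series, first, only, none or still open, it means among the compounds named here.

Going by the values given here, compound 2 `CC(C)(CCCCOc1cc(-c2ccc(C(F)(F)F)cc2)c2ccccc2n1)C(=O)O` gives 300 nM in an assay on membranes from spleen (Cavia porcellus) for binding affinity to leukotriene B4 receptor 1 (Homo sapiens) (on this read-out higher numbers stand for weaker inhibition and lower numbers for stronger inhibition), and holds the lowest number of the two values seen; compound 1 `O=C(O)CCCCCCOc1cc(-c2ccccc2)c2ccccc2n1` gives 1800 nM in this assay, a gap beyond the scatter, though the two structures differ in more than one place and so yield no single step. Compound 3 `CC(C)(CCCCOc1cc(-c2ccc(N)cc2)c2ccccc2n1)C(=O)O` carries the change amino in place of trifluoromethyl on an aromatic carbon relative to compound 2. Among the compounds with values here, no measured pair isolates this change, so its direction and size are open. Compound 3 is expected to land at 1500 nM, within 400 nM to 6000 nM. The expected step of a 5.0-fold higher number from compound 2 to compound 3 (0.70 log units; beyond the scatter) is a moderate rise, but it may well stay within the scatter.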

Compound 3, half-maximal inhibitory concentration: 40 nM
Compound 3: middle estimate off by 38-fold (1.57 log units), on the high side, and the stated range ends above it.
By their numbers in this assay, from the lowest: compound 3; then compound 2; then compound 1.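

In this assay the para position of the aryl ring proves sensitive to its substituent: amino in place of trifluoromethyl gives a 7.5-fold lower number from compound 2 to compound 3 (0.88 log units; beyond the scatter) and compound 3 now holds the lowest number of the three. The earlier pair differed in more than one place and could not isolate any effect at this carbon. No available evidence explains this step.

From the compounds shown here alone, whether a hydroxyl, methylamino or acetamide group at this carbon would give a similar number remains open. Also open, going by these compounds, is whether the amino step carries over to the chain of compound 1.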